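A few compounds are considered here, and "the series" means these few. Any claim that something is new, unique, unknown or untested is made for them only; others in the source may bear on it.

Of the compounds shown here, three built on one shared core have been measured in a functional assay on CHO cells for agonist activity at Alpha-2B adrenergic receptor (Homo sapiens); on this read-out higher numbers stand for an effect only at larger amounts of compound and lower numbers for an effect already at smaller amounts. Compound 1 `C=C(C)c1ccccc1OC(C)C1=NCCN1` gives 1580 nM. Compound 2 `CCOc1ccccc1OC(C)C1=NCCN1` gives 3160 nM. Compound 3 `C=COc1ccccc1OC(C)C1=NCCN1` gives 3160 nM, standing level with compound 2, the two together holding the highest numbers of the three; a 2.0-fold higher number from compound 1 to compound 3 (0.30 log units; within the scatter) and no change at the digits printed from compound 2 to compound 3 (within the scatter) both stay within the scatter. Compound 4 `CC(=O)c1ccccc1OC(C)C1=NCCN1` differs from compound 3 by acetyl in place of vinyloxy on an aromatic carbon. Among the compounds with values here, the steps that bear on this change are the exchanges of the same ring substituent already seen, a 2.0-fold higher number from compound 1 to compound 3 (0.30 log units; within the scatter) and no change at the digits printed from compound 2 to compound 3 (within the scatter), and neither moved the read-out beyond the scatter. Compound 4 is therefore expected to show a 1.3-fold lower number from compound 3 to compound 4 (0.10 log units; within the scatter), with no shift beyond the scatter anticipated. The estimate for compound 4 in this assay is 2500 nM, ranging from 800 nM to 8000 nM.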

Compound 4, half-maximal effective concentration: 295 nM
Estimate against measurement, compound 4: 8.5-fold (0.93 log units) above; the measured number lies below the stated range.
By their numbers in this assay, from the lowest: compound 4; then compounds 1, 2 and 3 (each within the scatter of the next).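

In this assay, this aromatic carbon proves sensitive to the group it carries, which the earlier exchanges did not reveal: acetyl gives a clearly lower number against vinyloxy (an 11-fold lower number from compound 3 to compound 4 (1.03 log units; beyond the scatter)), ethoxy (an 11-fold lower number from compound 2 to compound 4 (1.03 log units; beyond the scatter)) and 1-methylethenyl (a 5.4-fold lower number from compound 1 to compound 4 (0.73 log units; beyond the scatter)). Acetyl and vinyloxy have the same counts of heavy atoms, double bonds and hydrogen-bond acceptors, so these counts do not separate them. Nothing available explains the difference. From the compounds shown here alone, what an amide, a carboxylic acid or a propanoyl group would give on this carbon remains open.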